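Changing the Acyl Group on a Shared Core

This account rests on a few compounds, and the source may have more. Where it says the series, first, only, none or still open, it means among the compounds named here.

Measured in a functional assay on A549 cells (Homo sapiens) for cytotoxicity, read by MTT assay, with a stated time of 48 h; on this read-out lower numbers stand for stronger inhibition and higher numbers for weaker inhibition:
- Compound 1 `C=C1C(=O)O[C@H]2CC3=C[C@H](C/C(C)=C/[C@@H](OC(=O)CCl)[C@H]12)OC3=O`: > 10000 nM, a limit of the assay
- Compound 2 `C=C1C(=O)O[C@H]2CC3=C[C@H](C/C(C)=C/[C@@H](OC(=O)C4CC4)[C@H]12)OC3=O`: 3200 nM
- Compound 3 `C=C1C(=O)O[C@H]2CC3=C[C@H](C/C(C)=C/[C@@H](OC(=O)CC(C)C)[C@H]12)OC3=O`: 2500 nM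

Compound 2 has one close neighbour on these numbers, and the two cannot be told apart: a 1.3-fold lower number from compound 2 to compound 3 (0.11 log units; within the scatter). Compound 4 `C=C1C(=O)O[C@H]2CC3=C[C@H](C/C(C)=C/[C@@H](OC(=O)C4(NC(=O)OCc5ccccc5)CC4)[C@H]12)OC3=O` has not yet been measured. It carries (benzyloxycarbonyl)amino in place of hydrogen on a saturated ring carbon of the cyclopropyl group of compound 2 ((benzyloxycarbonyl)amino in place of hydrogen on a saturated ring carbon).

Three measured steps change the group on the carbonyl carbon. Two start from the limit of compound 1 and are beyond the scatter: an at least 3.1-fold lower number from compound 1 to compound 2 (0.49 log units; beyond the scatter) and an at least 4.0-fold lower number from compound 1 to compound 3 (0.60 log units; beyond the scatter). The third is the small step already given. None of them adds a group like this one, so they guide the size of the expected step only loosely. The expected step is a 1.1-fold higher number from compound 2 to compound 4 (0.04 log units; within the scatter), which means no clear shift in this assay is expected. For compound 4 the estimated value is 3500 nM, with an expected range from 1000 nM to 10000 nM.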

Compound 4, half-maximal inhibitory concentration: 5800 nM
Compound 4: middle estimate off by 1.7-fold (0.22 log units), on the low side; the range from low to high includes it.
By their numbers in this assay, from the lowest: compounds 3, 2 and 4 (each within the scatter of the next, the first and the last beyond it). At a limit, above all of these: compound 1.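

Adding (benzyloxycarbonyl)amino puts 11 heavy atoms, including one six-membered aromatic ring, on a saturated ring carbon of the cyclopropyl group of compound 2. In this assay, this large addition gives a 1.8-fold higher number from compound 2 to compound 4 (0.26 log units; within the scatter), so the assay does not separate compound 4 from compound 2, and this ring carbon can carry a bulky group without a clear shift in the read-out. Among the compounds shown, the only value that is a limit of the assay belongs to compound 1, and compound 4 gives a measured number: the limit of > 10000 nM in this assay, at which 1 of the 4 values shown sits.

One added group cannot show how the read-out depends on what sits at this ring carbon. A plain amine or a carboxylic acid at the same place could show whether the benzyl part of the group matters, and the compounds shown leave that open.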